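A Carbonyl Added to the Piperidin-1-yl Group

The source may hold more compounds than are shown below. What is called first, only, known or untested is meant among the compounds shown, and "the series" means these compounds.

Of the compounds shown here, three sharing one core have been tested in a functional assay on the whole organism (strain albino) for inhibition, with Rattus norvegicus as the target, read by paw edema, with a stated time of 1 h, at a dose of 20 mmol/kg by the intraperitoneal route; on this read-out higher numbers stand for more inhibition at the one dose given (going by the name of the read-out) and lower numbers for less inhibition. Compound 1 `N#CC1=C(NCN2CCCC2)N(c2ccccc2)C(=O)N2CCCCC(N3CCCC3)C12` gives 22.9% in this assay. Compound 2 `N#CC1=C(NCC(=O)N2CCCC2)N(c2ccccc2)C(=O)N2CCCCC(N3CCCC3)C12` gives 40.1%, and compound 3 `N#CC1=C(NCN2CCCCC2)N(c2ccccc2)C(=O)N2CCCCC(N3CCCC3)C12` gives 29.7%. Compound 3 thus stands second of the three numbers: its nearest neighbour is compound 1, the step of a number 6.8 percentage points higher from compound 1 to compound 3 (within the scatter) lying within the scatter, while the step of a number 10.4 percentage points lower from compound 2 to compound 3 (beyond the scatter) is beyond it.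

Compound 4 `N#CC1=C(NCC(=O)N2CCCCC2)N(c2ccccc2)C(=O)N2CCCCC(N3CCCC3)C12` is not yet measured. It differs from compound 3 at one place: (piperidin-1-yl)carbonyl in place of piperidin-1-yl on a saturated chain carbon bound to an amine nitrogen.

For the measured compounds named here, one measured step bears directly on this change. From compound 1 to compound 2 the same kind of alteration, a (pyrrolidin-1-yl)carbonyl in place of pyrrolidin-1-yl on a saturated chain carbon bound to an amine nitrogen, gave a number 17.2 percentage points higher from compound 1 to compound 2 (beyond the scatter). The step of a number 10.4 percentage points lower from compound 2 to compound 3 (beyond the scatter) points the same way, the carbonyl-bearing compound 2 sitting higher. On this basis an upward step of similar size to that from compound 1 to compound 2 is expected for compound 4, amounting to an estimated a number 15.3 percentage points higher from compound 3 to compound 4 (beyond the scatter). Compound 4 is therefore estimated at 45%, within a range from 32% to 58%.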

Compound 4, a percentage reported as inhibition, in the whole organism at one dose (the size of the read-out at that dose, not a potency): 38%
Estimate against measurement, compound 4: 7 percentage points above; the range from low to high includes it.
By their numbers in this assay, from the lowest: compounds 1, 3, 4 and 2 (each within the scatter of the next, the first and the last beyond it).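

In this assay, the carbonyl on a saturated chain carbon bound to an amine nitrogen now has a second reading, and with piperidin-1-yl as the ring it gives a number 8.3 percentage points higher from compound 3 to compound 4 (within the scatter) and stays within the scatter, whereas with pyrrolidin-1-yl it gave a number 17.2 percentage points higher from compound 1 to compound 2 (beyond the scatter) and went beyond it. Once the carbonyl is present, piperidin-1-yl in place of pyrrolidin-1-yl on a carbonyl carbon gives a number 2.1 percentage points lower from compound 2 to compound 4 (within the scatter), so the two rings cannot be told apart at this place, while the comparison of the carbonyl-bearing piperidin-1-yl compound with the first compound, a number 15.1 percentage points higher from compound 1 to compound 4 (beyond the scatter), again lies beyond the scatter. No measurement in hand accounts for any of these steps.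

The compounds shown leave open whether the carbonyl step would hold with a morpholin-4-yl group or an open-chain dimethylamino group on the carbonyl carbon in place of these two rings. They also leave open what a longer chain between the amino nitrogen and the carbonyl would do to the read-out.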